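From Methyl Ester to Free Acid at the Assay Limit

This account rests on a few compounds, and the source may have more. Where it says the series, first, only, none or still open, it means among the compounds named here.

In a functional assay on HeLa cells (Homo sapiens) for antiproliferative activity, read by MTT assay, with a stated time of 48 h (a lower number here means a stronger inhibitor, a higher number a weaker inhibitor), compound 1 `COC(=O)[C@H](CC(C)C)NC(=O)c1ccc(Oc2nc3ccccc3nc2C)cc1` gives 21600 nM, and compound 2 `CC[C@@H](C)[C@H](NC(=O)c1ccc(Oc2nc3ccccc3nc2C)cc1)C(=O)O` gives 33200 nM. Compound 3 `COC(=O)[C@H](CC(C)C)NC(=O)c1ccc(Oc2nc3ccccc3nc2NC(C)(C)C)cc1` returns only a limit of the assay, > 50000 nM, not a number. It is the only one of the three measured compounds at that limit, as the limit of > 50000 nM in this assay, at which 1 of the 3 values shown sits, records, and the step leading to it is an at least 2.3-fold higher number from compound 1 to compound 3 (0.36 log units; beyond the scatter).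

Compound 4 `CC(C)C[C@H](NC(=O)c1ccc(Oc2nc3ccccc3nc2NC(C)(C)C)cc1)C(=O)O` has hydrogen in place of methyl on an oxygen next to a carbonyl group, which turns methoxycarbonyl to carboxy. The closest measured step is a 1.5-fold higher number from compound 1 to compound 2 (0.19 log units; within the scatter). It makes the same exchange, but it yields 1-carboxy-2-methylbutyl rather than 1-carboxy-3-methylbutyl, so it is an imperfect guide. On that single step, no change beyond the scatter is expected in this assay, and a second reading at the limit would be unsurprising. Compound 4 is expected at 50000 nM, with an estimated range of 25000 nM to 100000 nM. The estimate amounts to a number no higher from compound 3 to compound 4 (the limit leaves the size open).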

Compound 4, half-maximal inhibitory concentration: 39200 nM
For compound 4 the middle estimate is 1.3-fold (0.11 log units) above the measured one; measured number inside the range.
By their numbers in this assay, from the lowest: compounds 1, 2 and 4 (each within the scatter of the next). At a limit, above all of these: compound 3.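

In this assay, carboxy in place of methoxycarbonyl is read here as a change in one place, on the 1-(methoxycarbonyl)-3-methylbutyl chain with (tert-butyl)amino on the shared core: an at least 1.2-fold lower number from compound 3 to compound 4 (0.10 log units; that floor lies within the scatter). For the compounds shown here, the earlier pair, compound 1 and compound 2, differed in the chain as well, ending in 1-carboxy-2-methylbutyl, so this is the first reading of the exchange with the chain held constant. The true size of the step stays unfixed because compound 3 has only a limit, not a number: the limit of > 50000 nM in this assay, at which 1 of the 4 values shown sits.

The compounds shown leave open how a primary amide or a hydroxymethyl group would read in place of carboxy on this chain. They also leave open whether an amine such as methylamino or morpholine would read differently from (tert-butyl)amino on the core.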